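This account rests on a few compounds, and the source may have more. Where it says the series, first, only, none or still open, it means among the compounds named here.

Of the compounds shown here, two built on a shared core have been tested in a functional assay on HepG2 cells (Homo sapiens) for antiproliferative activity, read by MTT assay, with a stated time of 48 h; a lower number here means a stronger inhibitor, a higher number a weaker inhibitor. Compound 1 `N#CC1=C(N)Oc2c(c3nc4ccccc4nc3c3ccccc23)C12C(=O)N(Cc1cnnn1-c1ccc(Br)cc1)c1ccccc12` gives a reading that is only a limit of the measurement, > 50000 nM. Compound 2 `N#CC1=C(N)Oc2c(N)cc3nc4ccccc4nc3c2C12C(=O)N(Cc1cnnn1-c1cccc(Br)c1)c1ccccc12` likewise gives only a limit, > 50000 nM. Both readings thus share (the limit of > 50000 nM in this assay, at which 2 of the 2 values shown sit), so compound 2 stands at the edge of what this assay can report, with no true number recorded for it. Compound 3 `Cc1ccc(C)c(-n2nncc2CN2C(=O)C3(C(C#N)=C(N)Oc4c(N)cc5nc6ccccc6nc5c43)c3ccccc32)c1` remains to be measured. It differs from compound 2 in one place (2,5-dimethylphenyl in place of 3-bromophenyl on an aromatic nitrogen). Among the measured compounds shown here, since no measured step between compounds exists here, there is nothing to gauge the size of a change against; the expectation in this assay is no shift beyond the usual scatter. Compound 3 is expected to give 60000 nM, with a range from 20000 nM to 200000 nM. The expected step is a step that the limit leaves unreadable from compound 2 to compound 3, most likely again ending at a limit rather than a number.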

Compound 3, half-maximal inhibitory concentration: > 50000 nM
Compound 3 ended at the assay's limit (the forecaster's own chance of this, stated with the estimate: 75%); the middle value does not contradict the limit.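

No step can be read from compound 2 to compound 3, since both end at a limit and not at a number: the limit of > 50000 nM in this assay, at which 3 of the 3 values shown sit. The compounds shown leave open how 2,5-dimethylphenyl and 3-bromophenyl truly compare in this assay, and whether any compound on this shared core gives a true number there.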